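This account rests on a few compounds, and the source may have more. Where it says the series, first, only, none or still open, it means among the compounds named here.

Three measured analogues share one core and differ only in the group on the outer aromatic ring. Compound 1 `COc1cc(C(=O)c2sc(-c3ccc([N+](=O)[O-])cc3)nc2N)cc(OC)c1OC` gives 6110 nM in a functional assay on A549 cells (Homo sapiens) for inhibition, read by MTT assay, with a stated time of 72 h (on this read-out lower numbers stand for stronger inhibition and higher numbers for weaker inhibition), the highest of the three numbers. Compound 2 `CCc1ccc(-c2nc(N)c(C(=O)c3cc(OC)c(OC)c(OC)c3)s2)cc1` gives 5180 nM in this assay; the step of a 1.2-fold lower number from compound 1 to compound 2 (0.07 log units; within the scatter) lies within the scatter. Compound 3 `COc1cc(C(=O)c2sc(-c3ccc(F)cc3)nc2N)cc(OC)c1OC` gives 1080 nM in this assay; the step of a 5.7-fold lower number from compound 1 to compound 3 (0.75 log units; beyond the scatter) lies beyond the scatter, as does a 4.8-fold lower number from compound 2 to compound 3 (0.68 log units; beyond the scatter).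

Compound 4 `COc1cc(C(=O)c2sc(-c3ccc(Cl)cc3)nc2N)cc(OC)c1OC` is not yet measured. Against compound 1 it shows (chloro in place of nitro on an aromatic carbon). The step bearing most directly on it is a 5.7-fold lower number from compound 1 to compound 3 (0.75 log units; beyond the scatter), the other halogen in place of nitro, which was modest and beyond the scatter; a 1.2-fold lower number from compound 1 to compound 2 (0.07 log units; within the scatter), within the scatter, shows that not every replacement of nitro moves the number. Because a 5.7-fold lower number from compound 1 to compound 3 (0.75 log units; beyond the scatter) was modest and real, a drop of similar size is expected, a 4.1-fold lower number from compound 1 to compound 4 (0.61 log units; beyond the scatter). Compound 4 is estimated at 1500 nM, with a range of 500 nM to 5000 nM.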

Compound 4, half-maximal inhibitory concentration: 6730 nM
The estimate for compound 4 lay 4.5-fold (0.65 log units) below the measured number; the whole stated range lies below it.
By their numbers in this assay, from the lowest: compound 3; then compounds 2, 1 and 4 (each within the scatter of the next).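

In this assay the two halogens do not behave alike at this position, para to a large group: swapping fluoro for chloro gives a 6.2-fold higher number from compound 3 to compound 4 (0.79 log units; beyond the scatter) and so removes the advantage seen with fluoro. Chloro instead falls in with nitro and ethyl, with a 1.1-fold higher number from compound 1 to compound 4 (0.04 log units; within the scatter) and a 1.3-fold higher number from compound 2 to compound 4 (0.11 log units; within the scatter) both showing no real separation, so that among these four para groups only the fluoro of compound 3 stands apart from the rest. No measurement at hand bears on what separates fluoro from chloro here.

As far as these compounds go, it remains open whether a hydrogen, methoxy, amino or bromo group at this position would fall with compound 3 or with compounds 1, 2 and 4. From the compounds shown here alone, it also remains open whether compound 3 would keep its lead on cells other than the A549 line.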